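A few compounds are considered here, and "the series" means these few. Any claim that something is new, unique, unknown or untested is made for them only; others in the source may bear on it.

Measured so far in a functional assay on the whole organism (stomach) with Rattus norvegicus as the target; on this read-out higher numbers stand for an effect only at larger amounts of compound and lower numbers for an effect already at smaller amounts:
compound 1 `N#CNC(=N)NCCCCCn1nc(-c2ccccc2)ccc1=O`; in this assay compound 1 gives > 100 mg/kg, which is a limit of the assay and not a number.
compound 2 `CC(C)(C)/N=C(\S)NCCCCn1nc(-c2ccccc2)ccc1=O`; in this assay compound 2 gives > 100 mg/kg, likewise a limit.

Compound 1 therefore stands only at a limit in this assay, and both values shown sit at the limit of > 100 mg/kg in this assay, at which 2 of the 2 values shown sit. For the measured compounds named here, the single measured step, a step that the two limits leave unreadable from compound 1 to compound 2, has no readable size, since the two limits leave it open.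

Compound 3 `CC/N=C(/NC#N)NCCCn1nc(-c2ccccc2)ccc1=O` differs from compound 1 by a group of 8 heavy atoms (4 carbon, 4 nitrogen; no ring) in place of a group of 8 heavy atoms (4 carbon, 4 nitrogen; no ring), on a saturated chain carbon, three bonds along the chain from an aromatic nitrogen. Going by the values given here, no measured step bears on this rearrangement; the only comparison available gives no size and no direction. The expectation for compound 3 can rest only on the limit of compound 1 and is weak. Compound 3 is expected at 150 mg/kg, in the range 40 mg/kg to 600 mg/kg, most likely again reported as a limit. The step that the limit leaves unreadable from compound 1 to compound 3 is thus expected to be none that can be resolved.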

Compound 3, dose for half-maximal effect: 78.3 mg/kg
Estimate against measurement, compound 3: 1.9-fold (0.28 log units) above, and the stated range covers the measured number.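

Compound 3 is the first compound here to give a number rather than a limit in this assay, so rearranging the same atoms at this place, on a saturated chain carbon, three bonds along the chain from an aromatic nitrogen, yields a value in a set otherwise held at one limit of the assay: the limit of > 100 mg/kg in this assay, at which 2 of the 3 values shown sit.

The change gives an at least 1.2-fold lower number from compound 1 to compound 3 (0.10 log units; that floor lies within the scatter), and this is only a floor, so neither a real gain nor its full size is established. The step between the two limits, from compound 1 to compound 2, cannot be read.

The compounds shown leave open how the number responds to a different group at this place, such as a primary amine or a carboxylic acid, or to a longer chain. With a single number in the set, no trend along the series can be stated.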